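The compounds below may be only part of what the source reports. "The series", "measured", "known", "first", "only" and "open" are said of these compounds alone.

Of the compounds shown here, three built on the same core have been measured in a functional assay (MiaPaCa cells, Homo sapiens) for inhibition, read by sulforhodamine B assay, with a stated time of 48 h; on this read-out lower numbers stand for stronger inhibition of growth and higher numbers for weaker inhibition of growth. Compound 1, `O=C(N/N=C\c1ccc(F)cc1)C1=C(Cl)c2ccccc2CCC1`, gives < 10 nM in this assay, which is a limit of the assay rather than a number. That reading sits at the limit of < 10 nM in this assay, at which 1 of the 3 values shown sits. Compound 2, `Cc1cc2c(cc1C)C(Cl)=C(C(=O)N/N=C\c1ccc(F)cc1)CCC2`, gives 360 nM in this assay. In compound 3, `O=C(N/N=C/C1=C(Cl)c2ccccc2CCC1)c1ccccc1`, the amide and the imine are swapped relative to compound 1. Compound 3 gives 1000 nM in this assay, the highest of the two numbers; its nearest neighbour is compound 2, whose number is lower by a gap that lies beyond the usual scatter.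

Compound 4, `O=C(N/N=C/C1=C(Cl)c2ccccc2CCC1)c1cccc(Cl)c1`, differs from compound 3 by chloro in place of hydrogen on an aromatic carbon. Among the compounds with values here, no measured pair shows what a change of this kind does here, so the size and direction of the step are open. The step from compound 3 to compound 4 is expected to be small, a 1.3-fold lower number from compound 3 to compound 4 (0.10 log units; within the scatter), with either direction possible and no change beyond the scatter the most likely outcome. Compound 4 is therefore estimated to give 800 nM in this assay, within a range from 200 nM to 3200 nM.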

Compound 4, concentration for 50% growth inhibition: 78400 nM
Compound 4: the middle estimate sits 98-fold (1.99 log units) below what was measured; the measured number lies above the stated range.
By their numbers in this assay, from the lowest: compound 2; then compound 3; then compound 4. At a limit, below all of these: compound 1.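

In this assay, within the data shown here, the change from phenyl to 3-chlorophenyl gives a 78-fold higher number from compound 3 to compound 4 (1.89 log units; beyond the scatter), the first step that can be read between two compounds differing in one place. It shows that this aromatic carbon, meta to a large group, does not tolerate every substituent: a single chlorine entering here is enough to weaken inhibition of growth strongly. Nothing in the data shown accounts for a step of this size.

From the compounds shown here alone, whether the loss is specific to chloro remains open, since fluoro, methyl or an amine at this place, or chloro elsewhere on the same ring, would be needed to tell. Going by these compounds, it is also open whether the same change would have a comparable effect in compounds with the amide and imine arranged as in compound 1.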